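This account rests on a few compounds, and the source may have more. Where it says the series, first, only, none or still open, it means among the compounds named here.

Compound 1 `Cc1[nH]c(=O)n(C)c1-c1ccccc1` gives > 100000 nM in a functional assay on brain (Rattus norvegicus, strain Wistar) for inhibition; a lower number here means a stronger inhibitor, a higher number a weaker inhibitor; this is a limit, not a number.
Compound 2 `CCCCn1c(-c2ccccc2)c(C)[nH]c1=O` gives > 100000 nM in this assay; this too is a limit.

Compound 1 therefore stands only at the limit of > 100000 nM in this assay, at which 2 of the 2 values shown sit, with no measured number of its own. The step that the two limits leave unreadable from compound 1 to compound 2 cannot be read in size. Compound 3 `Cc1[nH]c(=O)n(C)c1-c1ccc(OC(C)C)cc1` differs from compound 1 by isopropoxy in place of hydrogen on an aromatic carbon. Going by the values given here, no measured step bears on this change, so neither a direction nor a size beyond the scatter can be drawn from the data. For compound 3 the estimate in this assay is 100000 nM, with a range from 20000 nM to 500000 nM. The step of a number no higher from compound 1 to compound 3 (the limit leaves the size open) is thus expected to stay within the scatter, most likely as another limit.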

Compound 3, half-maximal inhibitory concentration: 20400 nM
Compound 3: the middle estimate sits 4.9-fold (0.69 log units) above what was measured, and the stated range covers the measured number.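

Isopropoxy on this aromatic carbon gives an at least 4.9-fold lower number from compound 1 to compound 3 (0.69 log units; beyond the scatter) in this assay, so this is the first change shown that moves the result beyond the scatter. Compound 3 is also the only compound of the three with a measured number, which gives later changes at this place a real value to be compared with: the limit of > 100000 nM in this assay, at which 2 of the 3 values shown sit.

As far as these compounds go, what remains open is whether the oxygen or the branched chain carries the gain. How a methoxy, a hydroxyl or an amine on the same carbon would compare is equally unknown.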